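From a butyl ester to an isopropylamide on one chain

The source may hold more compounds than are shown below. What is called first, only, known or untested is meant among the compounds shown, and "the series" means these compounds.

The measured compounds and their values:
compound 1, `CCCCOC(=O)/C=C(C)/C=C/CC(C)CCCC(C)(C)OC`, gives 6.62 in a physicochemical assay for lipophilicity; on this read-out lower numbers stand for lower lipophilicity and higher numbers for higher lipophilicity;
compound 2, `C=C(C)CCCC(C)C/C=C/C(C)=C/C(=O)OCC`, gives 6.19;
compound 3, `C=CCSC(=O)/C=C(C)/C=C/CC(C)CCCC(C)C`, gives 7.97.

Among these three numbers compound 1 stands second highest: compound 2 lies lower, beyond the scatter, and compound 3 lies higher, also beyond the scatter. The unmeasured compound 4, `COC(C)(C)CCCC(C)C/C=C/C(C)=C/C(=O)NC(C)C`, differs from compound 1 in one place: isopropylamino in place of butoxy on a carbonyl carbon. For the measured compounds named here, no measured pair shows this same change, so its size cannot be read off from these data. In this assay a downward step beyond the scatter is expected, a number 1.72 log units lower from compound 1 to compound 4 (beyond the scatter). Compound 4 is accordingly expected to give 4.9, with a range from 4.2 to 5.6.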

Compound 4, partition coefficient: 4.45
The estimate for compound 4 lay 0.45 log units above the measured number; the range from low to high includes it.
By their numbers in this assay, from the lowest: compound 4; then compound 2; then compound 1; then compound 3.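

In this assay, for the compounds shown here, putting isopropylamino in place of butoxy on a carbonyl carbon gives a number 2.17 log units lower from compound 1 to compound 4 (beyond the scatter) as the first step between measured compounds that differ in one place. The size of this change at this position can therefore now be read directly, and it is large. Nothing measured here accounts for its size. This single pair leaves open how much of the step comes from the swap of oxygen for nitrogen and how much from the chain itself. A butylamino group on the same carbonyl carbon would separate the two.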